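Swapping the aryl group on the saturated ring carbon

The compounds below may be only part of what the source reports. "The series", "measured", "known", "first", "only" and "open" are said of these compounds alone.

In a functional assay on Ehrlich cells (Mus musculus) for antiproliferative activity, read by trypan blue exclusion, with a stated time of 2 h, tested at 10 ug/mL (a higher number here means a stronger effect of the compound at the concentration tested, a lower number a weaker effect), compound 1 `N#CC1=C(N)N(c2ccc(S(N)(=O)=O)cc2)C2=C(C(=O)CCC2)C1c1ccc([N+](=O)[O-])cc1` gives 85% and compound 2 `N#CC1=C(N)N(c2ccc(S(N)(=O)=O)cc2)C2=C(C(=O)CCC2)C1c1ccc(Cl)cc1Cl` gives 40%, the lowest of the two numbers; the step of a number 45 percentage points lower from compound 1 to compound 2 (beyond the scatter) shows that the aryl group on the saturated ring carbon matters greatly. Compound 3 `COc1ccc2ccccc2c1C1C(C#N)=C(N)N(c2ccc(S(N)(=O)=O)cc2)C2=C1C(=O)CCC2` differs from compound 2 by 2-methoxynaphthalen-1-yl in place of 2,4-dichlorophenyl on a saturated ring carbon. Going by the values given here, no measured step covers this particular exchange, so only the size of that single step guides the expectation, and the direction is open. The expected step is a number 15 percentage points higher from compound 2 to compound 3 (beyond the scatter), giving an estimate for compound 3 of 55% within 25% to 85%.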

Compound 3, a percentage reported as activity, at one concentration (the size of the read-out at that concentration, not a potency): 40%
Estimate against measurement, compound 3: 15 percentage points above; measured number inside the range.
By their numbers in this assay, from the lowest: compounds 2 and 3 (each within the scatter of the next); then compound 1.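

In this assay the exchange gives no change at the digits printed from compound 2 to compound 3 (within the scatter), so two quite different aryl groups, one with a single aromatic ring and chlorine, the other with two aromatic rings and a methoxy group, give the same reading at this carbon. The second step, a number 45 percentage points lower from compound 1 to compound 3 (beyond the scatter), leaves compound 1 alone at the top of the three. Nothing available explains this. Still open, going by these compounds, is whether the high number of compound 1 depends on the nitro group itself, and whether an amine or a carboxylic acid in its place on the phenyl ring would keep it.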